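Swapping an aromatic amine for cyclopentylamino

A few compounds are considered here, and "the series" means these few. Any claim that something is new, unique, unknown or untested is made for them only; others in the source may bear on it.

compound 1 `CCc1ccc(NC2=CC(=O)c3c(nc4n3[C@H]3OC[C@@H](O)[C@H]3OC4)C2=O)cc1` gives 8990 nM
compound 2 `O=C1C=C(Nc2ccccc2F)C(=O)c2c1nc1n2[C@H]2OC[C@@H](O)[C@H]2OC1` gives 3640 nM
compound 3 `O=C1C(N2CCCC2)=CC(=O)c2c1nc1n2[C@H]2OC[C@@H](O)[C@H]2OC1` gives > 16000 nM (a limit)

In a functional assay on MCF7 cells (Homo sapiens) for inhibition, read by sulforhodamine B assay (on this read-out higher numbers stand for weaker inhibition and lower numbers for stronger inhibition), compound 2 at 3640 nM has the lower of the two exact numbers, and compound 1 at 8990 nM lies beyond the usual scatter from it. Compound 3 at > 16000 nM reports only a limit of the assay.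

The next compound is compound 4 `O=C1C=C(NC2CCCC2)C(=O)c2c1nc1n2[C@H]2OC[C@@H](O)[C@H]2OC1`, which has cyclopentyl in place of 2-fluorophenyl on an amine nitrogen.

Among the measured compounds shown here, one measured step bears on this, and only indirectly: an at least 1.7-fold higher number from compound 1 to compound 3 (0.25 log units; that floor lies within the scatter). It also replaces an aromatic ring with a non-aromatic one, but it is a different swap and gives only a floor, so it hints at direction more than size.

A higher number, meaning weaker inhibition, is therefore expected, with an estimated 2.2-fold higher number from compound 2 to compound 4 (0.34 log units; beyond the scatter) in this assay that remains uncertain. The estimate for compound 4 is 8000 nM with an expected range from 2800 nM to 22000 nM as its bounds.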

Compound 4, half-maximal inhibitory concentration: > 16000 nM
Compound 4 gave a limit, no number; the forecaster's own chance of this, stated with the estimate: 20%; middle value at least 2.0-fold (0.30 log units) from the limit.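

In this assay, changing only the group on the amine nitrogen, with the rest of the molecule held constant, gives an at least 4.3-fold higher number from compound 2 to compound 4 (0.64 log units; beyond the scatter). The earlier swap of an aromatic group for a non-aromatic one gave only a floor within the scatter, so this is the first such change shown to weaken inhibition beyond the scatter, though it rests on this single pair. Compound 4 gives > 16000 nM, which is a limit of the assay and not a number, so the full size of the step stays unknown: the limit of > 16000 nM in this assay, at which 2 of the 4 values shown sit.

This change removes the aromatic ring and the fluorine together and also alters the ring size, so the compounds shown cannot separate these differences. Plain phenyl or cyclohexyl on the same nitrogen would bear on that, and whether an open butyl chain behaves like cyclopentyl remains open.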